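Where hydroxycarbamoyl sits on the phenyl ring

The source may hold more compounds than are shown below. What is called first, only, known or untested is meant among the compounds shown, and "the series" means these compounds.

In a functional assay on HCT-116 cells (Homo sapiens) for cytotoxicity, read by MTT assay, with a stated time of 48 h (a higher number here means a weaker inhibitor, a lower number a stronger inhibitor), compound 1 `COc1cc(/C=C/c2ccc(OCCCCCCC(=O)NO)cc2)cc(OC)c1`, which carries a 5-(hydroxycarbamoyl)pentyl group, gives 1070 nM. Compound 2 `COc1cc(/C=C/c2ccc(OCc3ccccc3C(=O)NO)cc2)cc(OC)c1` gives 13900 nM, and compound 3 `COc1cc(/C=C/c2ccc(OCc3cccc(C(=O)NO)c3)cc2)cc(OC)c1` gives 13700 nM. The two phenyl compounds cannot be told apart on these numbers, with a step of a 1.0-fold lower number from compound 2 to compound 3 (0.01 log units; within the scatter). Both sit well above the pentyl compound, as the large steps of a 13-fold higher number from compound 1 to compound 2 (1.11 log units; beyond the scatter) and a 13-fold higher number from compound 1 to compound 3 (1.11 log units; beyond the scatter) show.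

Compound 4 `COc1cc(/C=C/c2ccc(OCc3ccc(C(=O)NO)cc3)cc2)cc(OC)c1` has the same atoms as its neighbour, joined differently: 4-(hydroxycarbamoyl)phenyl in place of 3-(hydroxycarbamoyl)phenyl on a saturated chain carbon bound to an oxygen on an aromatic ring. It keeps a phenyl group, so the two large steps away from the pentyl chain say little about this change. The closest guide is the shift between the two phenyl isomers, a 1.0-fold lower number from compound 2 to compound 3 (0.01 log units; within the scatter), which lies within the scatter. For the measured compounds named here, no measurement yet covers the 4-(hydroxycarbamoyl)phenyl group, so the range stays wide. No step beyond the scatter is expected, and the estimated step is a 1.4-fold lower number from compound 3 to compound 4 (0.14 log units; within the scatter). Compound 4 is expected at 10000 nM, within an estimated range of 3500 nM to 25000 nM.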

Compound 4, half-maximal inhibitory concentration: 10400 nM
Beside the measured number, compound 4's estimate is 1.0-fold (0.02 log units) below it; measured number inside the range.
By their numbers in this assay, from the lowest: compound 1; then compounds 4, 3 and 2 (each within the scatter of the next).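

In this assay, moving the hydroxycarbamoyl group to the third available place on the phenyl ring changes little: the 4-(hydroxycarbamoyl)phenyl group gives a 1.3-fold lower number from compound 3 to compound 4 (0.12 log units; within the scatter) and a 1.3-fold lower number from compound 2 to compound 4 (0.13 log units; within the scatter), so all three phenyl isomers now lie within the scatter of one another. The separation from the chain compound persists for this isomer too, at a 9.7-fold higher number from compound 1 to compound 4 (0.99 log units; beyond the scatter), so none of the three placements on the ring reaches the number of compound 1. No evidence is available to explain either the match among the isomers or their gap to the chain compound.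

The compounds shown leave open how a longer or shorter chain than 5-(hydroxycarbamoyl)pentyl would read in this assay. They also leave open whether a carboxylic acid in place of the hydroxycarbamoyl group, or a fluorine on the phenyl ring, would separate the isomers.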